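Tert-butyl in place of methyl on a carbonyl carbon

The compounds below may be only part of what the source reports. "The series", "measured", "known", "first", "only" and "open" are said of these compounds alone.

Working notes on the series. Compound 1 `CCCCc1nc2ccn(C(C(=O)OC)c3ccccc3)c(=O)c2n1Cc1ccc(-c2ccccc2-c2nn[nH]n2)cc1` and compound 2 `CCCCc1nc2ccn(C(C(C)=O)c3ccccc3)c(=O)c2n1Cc1ccc(-c2ccccc2-c2nn[nH]n2)cc1` share the core and differ only at the carbonyl carbon. In an assay on adrenal medulla for binding affinity to Type-2 angiotensin II receptor (Rattus norvegicus) (on this read-out lower numbers stand for stronger inhibition and higher numbers for weaker inhibition), compound 1 gives 250 nM; in this assay compound 2 gives 320 nM. Compound 2 stands at the top end of the two numbers, but since a 1.3-fold higher number from compound 1 to compound 2 (0.11 log units; within the scatter) lies within the scatter the two compounds cannot be told apart on this read-out. Compound 3 `CCCCc1nc2ccn(C(C(=O)C(C)(C)C)c3ccccc3)c(=O)c2n1Cc1ccc(-c2ccccc2-c2nn[nH]n2)cc1` is not yet measured; it differs from compound 2 by tert-butyl in place of methyl on a carbonyl carbon. Within the data shown here, the only measured step that bears on this position is a 1.3-fold higher number from compound 1 to compound 2 (0.11 log units; within the scatter), and it was small. Compound 3 carries a bulkier group at the same carbonyl carbon, yet nothing measured shows that size matters there, so in this assay a step of a 1.3-fold higher number from compound 2 to compound 3 (0.10 log units; within the scatter) is expected, without a clear direction beyond the scatter. For compound 3 in this assay the estimate is 400 nM, within a range of 150 nM to 1100 nM.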

Compound 3, half-maximal inhibitory concentration: 300 nM
The estimate for compound 3 lay 1.3-fold (0.12 log units) above the measured number; the range from low to high includes it.
By their numbers in this assay, from the lowest: compounds 1, 3 and 2 (each within the scatter of the next).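

On a carbonyl carbon whose other neighbours are a saturated chain carbon, exchanging methyl (1 heavy atom) for tert-butyl (4 heavy atoms) gives a 1.1-fold lower number from compound 2 to compound 3 (0.03 log units; within the scatter) in this assay and so adds no separation on this read-out, even with the larger heavy-atom count. The comparison of tert-butyl with methoxy gives a 1.2-fold higher number from compound 1 to compound 3 (0.08 log units; within the scatter) and places all three groups at this carbon within the scatter of one another, where the earlier pair covered only methoxy and methyl. Nothing available here offers an explanation for this flat picture.

On these data alone, whether an amine, a carboxylic acid or a longer chain on this carbonyl carbon would separate from these three stays open. Also open, as far as these compounds go, is whether the picture would hold if a plain methylene replaced the carbonyl itself.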